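Extending a Side Chain from Compound 1 to Compound 4

The source may hold more compounds than are shown below. What is called first, only, known or untested is meant among the compounds shown, and "the series" means these compounds.

Three compounds have been measured in a functional assay on HCT-116 cells (Homo sapiens) for inhibition, read by MTT assay, with a stated time of 48 h; a lower number here means a stronger inhibitor, a higher number a weaker inhibitor:

Compound 1, `COc1ccc(N(C)c2nc(C)nc3ccccc23)cc1OCCC[Se]C#N`, gives 852 nM.
Compound 2, `Cc1nc(N(C)c2ccc([Se]C#N)c(F)c2)c2ccccc2n1`, gives 20 nM.
Compound 3, `CN(c1ccc([Se]C#N)cc1)c1nc(C2CC2)nc2ccccc12`, gives 62 nM.

Compound 1 stands at the highest of these three numbers. The nearest to it is compound 3, whose number lies well beyond the scatter below; compound 2 lies further still. Compound 4, `COc1ccc(N(C)c2nc(C)nc3ccccc23)cc1OCCCCC[Se]C#N`, has not yet been measured. It differs from compound 1 in one place: a group of 5 heavy atoms (3 carbon, 1 nitrogen, 1 selenium; no ring) in place of a group of 3 heavy atoms (1 carbon, 1 nitrogen, 1 selenium; no ring), on a saturated chain carbon, three bonds along the chain from an oxygen on an aromatic ring. For the measured compounds named here, no measured pair shows a change of this kind, so the step of a 1.2-fold lower number from compound 1 to compound 4 (0.09 log units; within the scatter) is expected to stay within the scatter, in no firm direction. Compound 4 is therefore expected to give about 700 nM, with a range from 250 nM to 2000 nM.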

Compound 4, half-maximal inhibitory concentration: 256 nM
The estimate for compound 4 lay 2.7-fold (0.44 log units) above the measured number; the range from low to high includes it.
By their numbers in this assay, from the lowest: compound 2; then compound 3; then compound 4; then compound 1.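

In this assay, the side chain of the core of compound 1 proves sensitive to this change: the group of 5 heavy atoms in place of the group of 3 heavy atoms gives a 3.3-fold lower number from compound 1 to compound 4 (0.52 log units; beyond the scatter). For the compounds shown here, this is the first step that isolates a single place, and it shows that chain length alone can shift the number, though only modestly. No available evidence accounts for this step.

A single step establishes no trend with chain length. On these data alone, whether a longer chain would extend this step, or an amine or a carboxylic acid in place of this group would retain the activity, remains open.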